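A Third Methoxy Group on the Benzylamine Arm

The source may hold more compounds than are shown below. What is called first, only, known or untested is meant among the compounds shown, and "the series" means these compounds.

Of the compounds shown here, three built on one shared core have been measured. Compound 1 `Nc1cc(N)c2nc(-c3ccccc3)c(Oc3ccc(Cl)c(Cl)c3)nc2c1` gives 2140 nM in a functional assay on EKVX cells (Homo sapiens) for inhibition, read by sulforhodamine B assay, with a stated time of 48 h; a lower number here means a stronger inhibitor of growth, a higher number a weaker inhibitor of growth. Compound 2 `Nc1cc(N)c2nc(-c3ccccc3)c(NCc3ccc(Cl)c(Cl)c3)nc2c1` gives 11000 nM in this assay, and compound 3 `COc1ccc(CNc2nc3cc(N)cc(N)c3nc2-c2ccccc2)cc1OC` gives 5890 nM in this assay. Compound 3 sits close to compound 2, within the scatter, while its gap to compound 1, which has the lower number, lies beyond the scatter. Within the data shown here, the only measured step, a 1.9-fold lower number from compound 2 to compound 3 (0.27 log units; within the scatter), replaced the whole aryl group and stayed within the scatter. Compound 4 `COc1cc(CNc2nc3cc(N)cc(N)c3nc2-c2ccccc2)cc(OC)c1OC` carries a smaller change: methoxy in place of hydrogen on an aromatic carbon. Among the measured compounds shown here, no measured step adds a single methoxy group, so nothing bears directly on it, and the nearest comparison stayed within the scatter. A step of a 1.1-fold lower number from compound 3 to compound 4 (0.03 log units; within the scatter) is therefore expected, nothing beyond the scatter. Compound 4 is estimated at 5500 nM, with a range from 2000 nM to 15000 nM.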

Compound 4, concentration for 50% growth inhibition: 1950 nM
Estimate against measurement, compound 4: 2.8-fold (0.45 log units) above; the whole stated range lies above it.
By their numbers in this assay, from the lowest: compounds 4 and 1 (each within the scatter of the next); then compounds 3 and 2 (each within the scatter of the next).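

Adding a single methoxy group to the aromatic ring of the benzylamine arm gives a 3.0-fold lower number from compound 3 to compound 4 (0.48 log units; beyond the scatter) in this assay, the first step in this set to pass beyond the scatter. This position therefore responds to a small addition, although the larger swap of the whole aryl group from compound 2 to compound 3 stayed within the scatter. Nothing available explains why the number falls. Going by these compounds, what an ethoxy or hydroxyl group would do on this same aromatic carbon remains open, as does whether a lone methoxy group at this position would give a similar step.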